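Para-Methyl Carbamate Versus Fluoro Carbamate on a Selenocyanate Core

The source may report more compounds than this note shows. Statements on the series, on what has been measured and on what is new or still open speak of the compounds shown alone.

Three compounds measured so far:
compound 1 `N#C[Se]c1ccc(NC(=O)OCc2ccc([N+](=O)[O-])cc2)cc1`, 69500 nM;
compound 2 `N#C[Se]c1ccc(NC(=O)Oc2ccc(F)cc2)cc1`, 65700 nM;
compound 3 `CCCOC(=O)Nc1ccc([Se]C#N)cc1`, 67500 nM.

All three share a selenocyanate-bearing core with a carbamate, and all were tested in a functional assay on MCF7 cells (Homo sapiens) for cytotoxicity, read by MTT assay, with a stated time of 72 h; a higher number here means that more compound is tolerated, a lower number that less compound is tolerated. Compound 2 gives the lowest of the three numbers, but the gaps to compound 3 and to compound 1 both lie within the scatter, so the three values cannot be told apart.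

Compound 4 `Cc1ccc(OC(=O)Nc2ccc([Se]C#N)cc2)cc1` is the next candidate. It differs from compound 2 by methyl in place of fluoro on an aromatic carbon. For the measured compounds named here, no comparable step between measured compounds exists here. With the three known values sitting together, the step from compound 2 to compound 4 is expected to be none beyond the scatter, that is a 1.0-fold higher number from compound 2 to compound 4 (0.00 log units; within the scatter). Compound 4 is therefore estimated at 66000 nM, within a range from 33000 nM to 132000 nM.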

Compound 4, concentration lethal to 50% of the cells: 69800 nM
Beside the measured number, compound 4's estimate is 1.1-fold (0.02 log units) below it, and the stated range covers the measured number.
By their numbers in this assay, from the lowest: compounds 2, 3, 1 and 4 (each within the scatter of the next).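

In this assay, for the compounds shown here, the step of a 1.1-fold higher number from compound 2 to compound 4 (0.03 log units; within the scatter) is the first comparison here between compounds that differ in one place only. At this position, para to a large group, methyl and fluoro cannot be told apart, so this exchange leaves the cell result within the scatter. No measurement shown here gives any further insight into this result. As far as these compounds go, it remains open whether an amine, a carboxylic acid or a longer chain at this same position would give a number beyond the scatter of compound 2 and compound 4.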